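A few compounds are considered here, and "the series" means these few. Any claim that something is new, unique, unknown or untested is made for them only; others in the source may bear on it.

Working notes on the series. Compound 1 `CC(C)c1ccc(NC(=O)C2CCN(C/C=C/c3ccccc3)CC2)cc1` is the reference point here. In a functional assay on MGC-803 cells (Homo sapiens) for inhibition, read by MTT assay, with a stated time of 72 h (on this read-out higher numbers stand for weaker inhibition and lower numbers for stronger inhibition), compound 1 gives 5200 nM, the highest of the two numbers recorded so far. Among the measured compounds shown here, compound 2 `CCCCCc1ccc(NC(=O)C2CCN(C/C=C/c3ccccc3)CC2)cc1` is its nearest neighbour; in this assay compound 2 gives 2550 nM, and the step of a 2.0-fold lower number from compound 1 to compound 2 (0.31 log units; beyond the scatter) is the only measured step in the set, a change of the alkyl group on the aromatic carbon.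

Compound 3 `O=C(Nc1cccc(Br)c1)C1CCN(C/C=C/c2ccccc2)CC1` is not yet measured. It differs from compound 1 as follows: 3-bromophenyl in place of 4-isopropylphenyl on an amide-type nitrogen. For the measured compounds named here, no measured step touches the aryl group as a whole or a bromine substituent, so the step from compound 1 to compound 2 bears on this change only loosely. In this assay the step from compound 1 to compound 3 is therefore expected to stay within the scatter, a 1.0-fold lower number from compound 1 to compound 3 (0.02 log units; within the scatter). For compound 3 the estimated value in this assay is 5000 nM, with a range from 1800 nM to 14000 nM.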

Compound 3, half-maximal inhibitory concentration: 9110 nM
Compound 3: the middle estimate sits 1.8-fold (0.26 log units) below what was measured; the range from low to high includes it.
By their numbers in this assay, from the lowest: compound 2; then compounds 1 and 3 (each within the scatter of the next).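

The step shows something compound 2 could not: in this assay, the whole aryl group on the amide-type nitrogen can be exchanged, with bromine entering and the isopropyl group leaving, and the result is a 1.8-fold higher number from compound 1 to compound 3 (0.24 log units; within the scatter). Among the compounds shown here, earlier, only the alkyl group on the aromatic carbon had been varied, so this is the first reading on a change of substituent type at this position. No measured evidence bears on why the two aryl groups cannot be told apart in this assay.

The change swaps the substituent and its printed ring number together, so the contribution of each remains unresolved. Also open, on these data alone, is how this assay would respond to an amine or a carboxylic acid on this aryl group, or to an alkyl chain longer than pentyl.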